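N-aryl pyrazolone spiro-dienones: antiproliferative notes

The compounds below may be only part of what the source reports. "The series", "measured", "known", "first", "only" and "open" are said of these compounds alone.

Measured compounds:
compound 1 `CC1=NN(c2ccc(C)cc2)C(=O)C12C=CC(=O)C=C2c1cccc(C)c1` — 8340 nM
compound 2 `CC1=NN(c2ccc(C)cc2)C(=O)C12C=CC(=O)C=C2c1ccc(C)cc1` — 9710 nM
compound 3 `CC1=NN(c2ccc(Br)cc2)C(=O)C12C=CC(=O)C=C2c1ccccc1` — > 100000 nM

In a functional assay on HCT-116 cells (Homo sapiens) for antiproliferative activity, read by CCK-8 assay, with a stated time of 72 h (on this read-out higher numbers stand for weaker inhibition and lower numbers for stronger inhibition), compound 2 gives 9710 nM. It holds the highest of the two numbers shown; its nearest neighbour is compound 1, and the step of a 1.2-fold higher number from compound 1 to compound 2 (0.07 log units; within the scatter) lies within the scatter, so the two are not told apart. Compound 3 in this assay gives only a limit, > 100000 nM, and no number.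

Compound 4 `CC1=NN(c2cccc(Cl)c2)C(=O)C12C=CC(=O)C=C2c1ccc(C)cc1` is the next member. The change from compound 2 is 3-chlorophenyl in place of 4-methylphenyl on an amide-type nitrogen in a ring. For the measured compounds named here, no measured step bears on this position: the one measured step, from compound 1 to compound 2, concerns the aryl on the double-bonded ring carbon and lies within the scatter, so it gives no direction for the aryl on the ring nitrogen. Compound 3 carries a halogenated aryl on that nitrogen and sits at a limit, (the limit of > 100000 nM in this assay, at which 1 of the 3 values shown sits), but it differs from compound 2 in two places, so only its value itself is noted. On this basis compound 4 is expected to give a weaker number than compound 2, with a real chance of a limit; the expected step is a 3.6-fold higher number from compound 2 to compound 4 (0.56 log units; beyond the scatter). The estimate for compound 4 is 35000 nM, with a range from 9000 nM to 100000 nM.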

Compound 4, half-maximal inhibitory concentration: 2400 nM
Beside the measured number, compound 4's estimate is 15-fold (1.16 log units) above it; the measured number lies below the stated range.
By their numbers in this assay, from the lowest: compound 4; then compounds 1 and 2 (each within the scatter of the next). At a limit, above all of these: compound 3.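

In this assay, the aryl on an amide-type nitrogen in a ring is the one position shown where a single change moves the number beyond the scatter: 3-chlorophenyl in place of 4-methylphenyl gives a 4.0-fold lower number from compound 2 to compound 4 (0.61 log units; beyond the scatter). A chlorine-bearing aryl at this position therefore brings no limit and gives the lowest number of the compounds shown, while nothing measured here accounts for the step. For compound 3 only a limit is given, > 100000 nM, not a number, and it differs from compound 4 in two places, so the two are not compared.

For the compounds shown here, only one step at this position can be read, so it stays open whether the change follows from the chlorine, from its place on the phenyl ring or from the loss of the methyl, and how a phenyl carrying a methoxy group, an amine or a carboxylic acid would behave on that nitrogen. Also open, going by these compounds, is whether the step carries over to the 3-methylphenyl on the double-bonded ring carbon of compound 1.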